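Aryl substituent swap: trifluoromethyl for phenyl in the series

The source may hold more compounds than are shown below. What is called first, only, known or untested is meant among the compounds shown, and "the series" means these compounds.

Three compounds share a core and differ only at one aromatic carbon. In a functional assay on HGC-27 cells (Homo sapiens) for inhibition, read by MTT assay, with a stated time of 72 h (on this read-out higher numbers stand for weaker inhibition and lower numbers for stronger inhibition), compound 1 `COc1ccc(N2CCCC2)c(C(=O)Nc2ccc(CNC(=O)OCc3cccnc3)cc2)c1` gives 138000 nM, compound 2 `O=C(NCc1ccc(NC(=O)c2cc(Br)ccc2N2CCCC2)cc1)OCc1cccnc1` gives 640 nM, and compound 3 `O=C(NCc1ccc(NC(=O)c2cc(-c3ccccc3)ccc2N2CCCC2)cc1)OCc1cccnc1` gives 4340 nM. Compound 3 stands second highest of the three numbers: a 6.8-fold higher number from compound 2 to compound 3 (0.83 log units; beyond the scatter), while a 32-fold lower number from compound 1 to compound 3 (1.50 log units; beyond the scatter). The bromo compound is the lowest number among them, with a 220-fold lower number from compound 1 to compound 2 (2.33 log units; beyond the scatter).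

For the measured compounds named here, compound 4 `O=C(NCc1ccc(NC(=O)c2cc(C(F)(F)F)ccc2N2CCCC2)cc1)OCc1cccnc1` is the next point. trifluoromethyl in place of phenyl on an aromatic carbon The step that bears most directly is the one between compound 2 and compound 3, where the replacement of bromo by phenyl raised the number by a modest amount; the step from compound 1 to compound 3 shows that any substituent other than methoxy here gives a large drop. A trifluoromethyl group is nearer in size to bromo than to phenyl, so the expectation is a modest reduction from compound 3, a 2.9-fold lower number from compound 3 to compound 4 (0.46 log units; beyond the scatter), though not necessarily all the way to the bromo value. Compound 4 is therefore estimated at 1500 nM in this assay, with a range of 400 nM to 6000 nM.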

Compound 4, half-maximal inhibitory concentration: 790 nM
Estimate against measurement, compound 4: 1.9-fold (0.28 log units) above, and the stated range covers the measured number.
By their numbers in this assay, from the lowest: compounds 2 and 4 (each within the scatter of the next); then compound 3; then compound 1.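

In this assay, trifluoromethyl on this aromatic carbon, para to a pyrrolidin-1-yl group, returns the number to the low level that phenyl had left, with a 5.5-fold lower number from compound 3 to compound 4 (0.74 log units; beyond the scatter). Against bromo the change cannot be told apart from scatter, with a 1.2-fold higher number from compound 2 to compound 4 (0.09 log units; within the scatter), so bromo and trifluoromethyl stand level here and phenyl sits apart from both. The large step away from methoxy, a 170-fold lower number from compound 1 to compound 4 (2.24 log units; beyond the scatter), now holds for all three replacements, and compound 1 has the highest number of the four.

Nothing measured here accounts for why these groups fall in this order. As far as these compounds go, whether a nitrile, an amine or a carboxylic acid on this carbon would stay at the level of bromo and trifluoromethyl, or move towards that of methoxy, remains open.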